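A few compounds are considered here, and "the series" means these few. Any claim that something is new, unique, unknown or untested is made for them only; others in the source may bear on it.

Working notes on a small thioether series built on one shared core. Compound 1 `C#CCNC1CCc2c(SCCc3cccc(C(F)(F)F)c3)cccc21` and compound 2 `C#CCNC1CCc2c(SCCc3cccc(Br)c3)cccc21` carry the same linker to the aryl ring, while compound 3 `C#CCNC1CCc2c(SCc3cccc(Br)c3)cccc21` and the untested compound 4 `C#CCNC1CCc2c(SCc3cccc(C(F)(F)F)c3)cccc21` carry a shorter one. In an ADME assay on isolated protein for inhibition of Amine oxidase [flavin-containing] B (Homo sapiens) (on this read-out lower numbers stand for stronger inhibition and higher numbers for weaker inhibition), compound 1 gives 280 nM and compound 2 gives 620 nM. The step of a 2.2-fold lower number from compound 2 to compound 1 (0.35 log units; beyond the scatter) is a modest gain, and the change behind it is trifluoromethyl in place of bromo on an aromatic carbon. In this assay compound 3 gives only a limit of the assay, > 100000 nM. The difference between the cores of compound 2 and compound 3 is not broken down here. Compound 4 differs from compound 3 by trifluoromethyl in place of bromo on an aromatic carbon, the same change as from compound 2 to compound 1, at a place described in identical words. Because compound 3 sits at the limit of > 100000 nM in this assay, at which 1 of the 3 values shown sits, a gain of the size of a 2.2-fold lower number from compound 2 to compound 1 (0.35 log units; beyond the scatter) is expected to leave compound 4 close to that limit. For compound 4 the expected step is a step that the limit leaves unreadable from compound 3 to compound 4. Compound 4 is therefore estimated at 120000 nM, between 30000 nM and 500000 nM, with a good chance that this assay again returns only a limit.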

Compound 4, half-maximal inhibitory concentration: 7710 nM
Compound 4: the middle estimate sits 16-fold (1.19 log units) above what was measured; the measured number lies below the stated range.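

In this assay, trifluoromethyl in place of bromo on an aromatic carbon gives an at least 12-fold lower number from compound 3 to compound 4 (1.11 log units; beyond the scatter), and the direction matches the earlier pair while the size does not carry over from one core to the other: the same change on two cores in this assay, a 2.2-fold lower number (0.35 log units; beyond the scatter) from compound 2 to compound 1 and an at least 12-fold lower number (1.11 log units; beyond the scatter) from compound 3 to compound 4, at least 5.8-fold (0.76 log units) apart, beyond the scatter of two such steps Compound 3 stands at a limit of the assay and not at a number, so the step on its core is known only as a minimum: the limit of > 100000 nM in this assay, at which 1 of the 4 values shown sits. These two pairs show that the same change can differ in size between the two cores, but they do not show why, and they give no rule for any other core in the series.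

The compounds shown leave open whether chloro or a nitrile on the same aromatic carbon would behave alike on both cores. Also open, as far as these compounds go, is how a longer chain between the sulfur and the aryl ring would change the size of this step.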